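The source may hold more compounds than are shown below. What is called first, only, known or untested is meant among the compounds shown, and "the series" means these compounds.

Measured so far:
Compound 1 `Cc1ccc(/C=N/NC(=S)N2CCNCC2)cc1`: 800 nM
Compound 2 `S=C(N/N=C/c1ccccc1)N1CCNCC1`: 2410 nM

In a functional assay on HBL-100 cells (Homo sapiens) for antiproliferative activity, read by MTT assay, with a stated time of 72 h (on this read-out higher numbers stand for weaker inhibition and lower numbers for stronger inhibition), compound 2 gives 2410 nM, the highest of the two numbers; the nearest is compound 1 with 800 nM. Compound 3 `S=C(N/N=C/c1ccc(Cl)cc1)N1CCNCC1` differs from compound 2 by chloro in place of hydrogen on an aromatic carbon. Among the measured compounds shown here, the only measured step, a 3.0-fold higher number from compound 1 to compound 2 (0.48 log units; beyond the scatter), concerns a methyl rather than a chloro, so no measured step bears directly on this change, and the direction is open. Compound 3 is therefore expected to give about 1200 nM in this assay, between 400 nM and 3500 nM, an estimated step of a 2.0-fold lower number from compound 2 to compound 3 (0.30 log units; within the scatter) that stays near the scatter.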

Compound 3, half-maximal inhibitory concentration: 1600 nM
For compound 3 the middle estimate is 1.3-fold (0.12 log units) below the measured one; low and high end bracket the measured number.
By their numbers in this assay, from the lowest: compounds 1, 3 and 2 (each within the scatter of the next, the first and the last beyond it).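

In this assay chloro on this aromatic carbon, para to a large group, gives a 1.5-fold lower number from compound 2 to compound 3 (0.18 log units; within the scatter) when it replaces hydrogen. When it replaces methyl, the result is a 2.0-fold higher number from compound 1 to compound 3 (0.30 log units; within the scatter) and so compound 3 cannot be separated from either compound 1 or compound 2, although those two lie beyond the scatter of each other. No supporting evidence explains this result.

The compounds shown leave open how a methoxy group, an amine or a carboxylic acid would read at this place. They also leave open whether chloro would read alike elsewhere on the ring.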